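Swapping hydroxy for amino on a second core

This account rests on a few compounds, and the source may have more. Where it says the series, first, only, none or still open, it means among the compounds named here.

Of the compounds shown here, three have so far been tested in a functional assay on P388 cells (Mus musculus) for inhibition; on this read-out higher numbers stand for an effect only at larger amounts of compound and lower numbers for an effect already at smaller amounts. Compound 1, `Nc1nc(O)c2ncn(C3CCC(CO)C3)c2n1`, gives only a limit in this assay, > 100 ug/mL. Compound 2, `Nc1nc(N)c2ncn(C3CCC(CO)C3)c2n1`, differs from compound 1 by amino in place of hydroxy on an aromatic carbon, and in this assay compound 2 gives 80 ug/mL. The step of an at least 1.2-fold lower number from compound 1 to compound 2 (0.09 log units; that floor lies within the scatter) can only be stated as a floor because of the limit of > 100 ug/mL in this assay, at which 1 of the 3 values shown sits. Compound 3, `Nc1nc(O)c2nnn(C3C=CC(CO)C3)c2n1`, is built on a different core; how its core differs from the core of compound 1 is not broken down here. In this assay compound 3 gives 4.5 ug/mL, the lowest of the two numbers available, and it stands well apart from compound 2.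

Compound 4, `Nc1nc(N)c2nnn(C3C=CC(CO)C3)c2n1`, has not yet been measured. It differs from compound 3 by amino in place of hydroxy on an aromatic carbon, the same change that leads from compound 1 to compound 2, at a place described in exactly the same words. In that one measured instance the change moved the number only a little, and at most somewhat downward. For the measured compounds named here, for compound 4 the expected step in this assay is therefore a 1.3-fold lower number from compound 3 to compound 4 (0.11 log units; within the scatter), which rests on the single measured step of an at least 1.2-fold lower number from compound 1 to compound 2 (0.09 log units; that floor lies within the scatter) as the only guide to what this change does. The estimate for compound 4 in this assay is 3.5 ug/mL, with the likely range expected to run from 1.2 ug/mL to 12 ug/mL.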

Compound 4, concentration for half-maximal effect: > 100 ug/mL
Compound 4: a limit, no number (the forecaster's own chance of this, stated with the estimate: 5%); middle value at least 28-fold (1.45 log units) away from the limit.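

On the core of compound 3, amino in place of hydroxy on an aromatic carbon gives an at least 22-fold higher number from compound 3 to compound 4 (1.34 log units; beyond the scatter) in this assay, a large step, whereas the same change on the core of compound 1 gave no step beyond the scatter. What this change does on one core therefore cannot be taken as a guide to what it does on the other, and the estimate built on that assumption did not hold: the same change on two cores in this assay, an at least 1.2-fold lower number (0.09 log units; that floor lies within the scatter) from compound 1 to compound 2 and an at least 22-fold higher number (1.34 log units; beyond the scatter) from compound 3 to compound 4, at least 27-fold (1.44 log units) apart, beyond the scatter of two such steps. For the compounds shown here, this is only one comparison of two pairs, however, and it does not show which of the differences between the two cores matters, nor how large either step really is, since each rests on a value that is a limit and not a number: the limit of > 100 ug/mL in this assay, at which 2 of the 4 values shown sit.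

The compounds shown leave open whether the good number of compound 3, 4.5 ug/mL, depends on hydroxy specifically or whether other groups at that place, such as methoxy, a thiol or a chlorine atom, would keep it. They also leave open whether a small amine such as methylamino would behave like amino on this core.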